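The source may report more compounds than this note shows. Statements on the series, on what has been measured and on what is new or still open speak of the compounds shown alone.

Measured compounds in an assay on HEK293 cells for inhibition of Voltage-dependent T-type calcium channel subunit alpha-1G (Homo sapiens), read by fluorescence, tested at 10 uM; a lower number here means less inhibition, a higher number more inhibition at the concentration tested (going by the name of the read-out):
compound 1 `CCCc1nc(-c2ccccc2)c(CNCCN2CCN(c3ccc(Cl)cc3)CC2)o1`: 55.8%
compound 2 `CCCc1nc(-c2ccccc2)c(CNCCN2CCN(c3ccc(OC)cc3)CC2)o1`: 51.5%

Among the measured compounds shown here, compound 2 stands at 51.5% in this assay, and the only measured step, a number 4.3 percentage points lower from compound 1 to compound 2 (within the scatter), lies within the scatter, so compound 1 and compound 2 cannot be told apart on these numbers. The next compound, compound 3 `CCCc1nc(-c2ccccc2)c(CNCCN2CCN(c3ccccn3)CC2)o1`, differs from compound 2 by a single change: pyridin-2-yl in place of 4-methoxyphenyl on an amine nitrogen in a ring. For the measured compounds named here, no measured step touches this exchange; the one step available swaps methoxy for chloro on the same aromatic ring and stays within the scatter, so the number in this assay stays level across that exchange, but it says nothing about a pyridin-2-yl. He therefore expects a step of a number 3.5 percentage points lower from compound 2 to compound 3 (within the scatter) that stays within the usual scatter, though with a wider band of uncertainty than the measured pair would suggest. For compound 3 he estimates 48% in this assay, within a range from 30% to 65%.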

Compound 3, a percentage reported as inhibition, at one concentration (the size of the read-out at that concentration, not a potency): 48.1%
For compound 3 the middle estimate is 0.1 percentage points below the measured one, and the stated range covers the measured number.
By their numbers in this assay, from the lowest: compounds 3, 2 and 1 (each within the scatter of the next).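

In this assay, the earlier pair exchanged only methoxy and chloro on an aromatic carbon, while compound 3 replaces the whole aromatic group on the amine nitrogen in the ring. Pyridin-2-yl in place of 4-methoxyphenyl gives a number 3.4 percentage points lower from compound 2 to compound 3 (within the scatter), and pyridin-2-yl in place of 4-chlorophenyl gives a number 7.7 percentage points lower from compound 1 to compound 3 (within the scatter), so a ring with one hetero atom and without the earlier substituents cannot be told apart from either phenyl compound at this place. Nothing given here bears on why these numbers stay so close.

From the compounds shown here alone, it remains open whether a cyclohexyl or a benzyl group on that ring nitrogen would also stay within the scatter in this assay. The same holds for a carboxylic acid or an amine on the aromatic ring.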